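The source may hold more compounds than are shown below. What is called first, only, known or untested is meant among the compounds shown, and "the series" means these compounds.

Compound 1 `Cc1ccc(OCc2nnc(C(=O)Nc3ccc(CCC(=O)O)cc3)s2)cc1C` stands at the lower of the two numbers recorded so far in a functional assay on CHO cells for agonist activity at Free fatty acid receptor 1 (Homo sapiens), read by FLIPR and calcium flux, tested at 1 uM (on this read-out lower numbers stand for an effect already at smaller amounts and higher numbers for an effect only at larger amounts of compound), where compound 1 gives 1130 nM. Within the data shown here, its closest neighbour is compound 2 `COc1ccc(OCc2nnc(C(=O)Nc3ccc(CCC(=O)O)cc3)s2)cc1`, which in this assay gives 2430 nM; the single change between them, a 4-methoxyphenyl in place of the 3,4-dimethylphenyl on the oxygen, brings a 2.2-fold higher number from compound 1 to compound 2 (0.33 log units; beyond the scatter). Compound 3 `O=C(O)CCc1ccc(NC(=O)c2nnc(Cc3ccccc3)s2)cc1` has not been measured. It differs from compound 1 by phenyl in place of 3,4-dimethylphenoxy on a saturated chain carbon bound to an aromatic carbon: the oxygen link disappears together with both methyl groups, leaving a bare ring. Among the measured compounds shown here, the one measured step bears on it only loosely, since that step altered the ring while keeping the oxygen, yet it did move the number upward when the ring lost its methyls. A shift in the same direction, somewhat larger, is therefore expected in this assay for compound 3, about a 2.5-fold higher number from compound 1 to compound 3 (0.39 log units; beyond the scatter). Compound 3 is thus estimated at 2800 nM, within a range of 1000 nM to 8000 nM.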

Compound 3, half-maximal effective concentration: 3670 nM
Compound 3: the middle estimate sits 1.3-fold (0.12 log units) below what was measured; the measured number falls inside the stated range.
By their numbers in this assay, from the lowest: compound 1; then compounds 2 and 3 (each within the scatter of the next).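

The earlier compounds shown here changed only the ring and kept the oxygen, whereas compound 3 shows what happens when the whole group on a saturated chain carbon bound to an aromatic carbon is replaced. In this assay, phenyl in place of 3,4-dimethylphenoxy gives a 3.2-fold higher number from compound 1 to compound 3 (0.51 log units; beyond the scatter) and so a modest change, while phenyl in place of 4-methoxyphenoxy gives a 1.5-fold higher number from compound 2 to compound 3 (0.18 log units; within the scatter) and does not separate the two compounds. Of these three groups, only 3,4-dimethylphenoxy stands apart beyond the scatter, and no measurement here offers a reason for this.

From the compounds shown here alone, the step from compound 1 to compound 3 removes the oxygen and both methyl groups together, so their separate contributions remain unknown. A plain phenoxy or a 3,4-dimethylphenyl at this place would pull the two apart.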